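Removing the whole side chain from compound 3

The source may hold more compounds than are shown below. What is called first, only, known or untested is meant among the compounds shown, and "the series" means these compounds.

Three compounds sharing one pentacyclic core carry different groups on the nitrogen of its five-membered ring. Compound 1, `CN1CCN(CCCCCn2c3c(c4ccccc42)C(=O)c2c[n+]([O-])c4ccccc4c2C3=O)CC1`, gives 1710 nM in a functional assay on A-375 cells (Homo sapiens) for cytotoxicity, read by MTT assay, with a stated time of 72 h; on this read-out higher numbers stand for weaker inhibition and lower numbers for stronger inhibition. Compound 2, `O=C1c2c[n+]([O-])c3ccccc3c2C(=O)c2c1c1ccccc1n2Cc1cn([C@H]2C[C@H](O)[C@@H](CO)O2)nn1`, gives 390 nM. Compound 3, `O=C1c2c[n+]([O-])c3ccccc3c2C(=O)c2c1c1ccccc1n2Cc1cn(C[C@@H](O)CO)nn1`, gives 140 nM, the lowest number of the three: the step of a 12-fold lower number from compound 1 to compound 3 (1.09 log units; beyond the scatter) is a large one, and the step of a 2.8-fold lower number from compound 2 to compound 3 (0.44 log units; beyond the scatter) is modest. So the side chain on that nitrogen clearly matters, and the 1-(2,3-dihydroxypropyl)-1H-1,2,3-triazol-4-yl group has done best so far.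

Compound 4, `O=C1c2c[n+]([O-])c3ccccc3c2C(=O)c2[nH]c3ccccc3c21`, goes further than either earlier step: hydrogen in place of (1-(2,3-dihydroxypropyl)-1H-1,2,3-triazol-4-yl)methyl on an aromatic nitrogen. Going by the values given here, nothing in the measured set shows the bare nitrogen, so the expectation rests only on the observation that every side chain tried gave a different number and that the one on compound 3 gave the strongest inhibition. Taking the side chain away altogether is therefore expected to weaken inhibition, with a step of about a 4.3-fold higher number from compound 3 to compound 4 (0.63 log units; beyond the scatter), though the uncertainty is wide. For compound 4 the estimate is 600 nM, within a range of 150 nM to 3000 nM.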

Compound 4, half-maximal inhibitory concentration: 660 nM
Compound 4: the middle estimate sits 1.1-fold (0.04 log units) below what was measured; measured number inside the range.
By their numbers in this assay, from the lowest: compound 3; then compounds 2 and 4 (each within the scatter of the next); then compound 1.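

With hydrogen on the aromatic nitrogen, compound 4 gives this position its first reference point in this assay: the shared core inhibits without any side chain, and compound 4 reaches 660 nM on its own. Against that reference, the side chains do not all act in the same direction: taking away the (1-(2,3-dihydroxypropyl)-1H-1,2,3-triazol-4-yl)methyl group gives a 4.7-fold higher number from compound 3 to compound 4 (0.67 log units; beyond the scatter) and so weakens inhibition, while taking away the 5-(4-methylpiperazin-1-yl)pentyl group gives a 2.6-fold lower number from compound 1 to compound 4 (0.41 log units; beyond the scatter) and so strengthens it, which means that the identity of the group, not merely the presence of one, sets the direction of the step. No experimental evidence at hand explains this difference in direction.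

The compounds shown leave open which part of the better side chain carries the gain, the triazole ring or the two hydroxyl groups of the 2,3-dihydroxypropyl group. A triazole ring carrying only a methyl group, or a simple 2-hydroxyethyl chain on the same nitrogen, would begin to separate those two parts.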